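A hydroxyphenyl swap on a cytotoxic urea series

This account rests on a few compounds, and the source may have more. Where it says the series, first, only, none or still open, it means among the compounds named here.

Of the compounds shown here, three sharing one core have been tested in a functional assay on MKN-45 cells (Homo sapiens) for cytotoxicity, read by MTT assay, with a stated time of 72 h; on this read-out lower numbers stand for stronger inhibition and higher numbers for weaker inhibition. Compound 1 `COc1ccc(OC)c(/C=N/NC(=O)Nc2ccc(Oc3ccnc(-c4nncn4CCN(C)C)c3)c(F)c2)c1` gives 1510 nM and stands second highest of the three numbers; its nearest neighbour is compound 3 `CN(C)CCn1cnnc1-c1cc(Oc2ccc(NC(=O)N/N=C/c3ccc(O)c(F)c3)cc2F)ccn1`, which gives 1970 nM, while compound 2 `CN(C)CCn1cnnc1-c1cc(Oc2ccc(NC(=O)N/N=C/c3cccc(Cl)c3Cl)cc2F)ccn1`, with 51 nM, lies furthest away. The step of a 1.3-fold higher number from compound 1 to compound 3 (0.12 log units; within the scatter), whereas the step of a 30-fold lower number from compound 1 to compound 2 (1.47 log units; beyond the scatter), so only the dichlorophenyl group has so far moved this read-out by a clear margin.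

Compound 4 `CN(C)CCn1cnnc1-c1cc(Oc2ccc(NC(=O)N/N=C/c3ccc(O)cc3)cc2F)ccn1` has not yet been measured in this assay . It differs from compound 1 by 4-hydroxyphenyl in place of 2,5-dimethoxyphenyl on a carbon with a double bond to nitrogen. For the measured compounds named here, the step that bears most directly on it is the one to compound 3, since compound 3 carries the same hydroxyphenyl pattern with one extra fluorine, and that step stayed within the scatter. The large gain seen in the step to compound 2 came from a different kind of group and offers no guide here. The expected outcome is therefore a change of no more than the usual scatter, possibly a slightly higher number, so the estimated step is a 1.3-fold higher number from compound 1 to compound 4 (0.12 log units; within the scatter). Compound 4 is expected to give about 2000 nM, with a likely range from 700 nM to 6000 nM.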

Compound 4, half-maximal inhibitory concentration: 820 nM
Compound 4: middle estimate off by 2.4-fold (0.39 log units), on the high side, within the range that was stated.
By their numbers in this assay, from the lowest: compound 2; then compounds 4, 1 and 3 (each within the scatter of the next, the first and the last beyond it).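

For the compounds shown here, the pair of compound 3 and compound 4 is the first to isolate one small change on the hydroxyphenyl group: hydrogen in place of fluoro on an aromatic carbon gives a 2.4-fold lower number from compound 3 to compound 4 (0.38 log units; beyond the scatter) in this assay, a modest shift but one beyond the scatter. Replacing 2,5-dimethoxyphenyl with the smaller 4-hydroxyphenyl, which has a hydrogen-bond donor that the leaving group lacks, gives a 1.8-fold lower number from compound 1 to compound 4 (0.27 log units; within the scatter), so these two groups cannot be told apart on this read-out, whereas a 16-fold higher number from compound 2 to compound 4 (1.21 log units; beyond the scatter) confirms that compound 2, with its 2,3-dichlorophenyl group, remains the most potent of the four. Nothing available offers a measured explanation for any of these differences.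

The compounds shown leave open how an unsubstituted phenyl group, or a phenyl group carrying a single chlorine, would read at this position. Without such a comparison, they cannot show whether one chlorine would be enough to give much of the potency of compound 2, or whether both chlorines are needed.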